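Swapping the Aryl Group on a Shared Core

A few compounds are considered here, and "the series" means these few. Any claim that something is new, unique, unknown or untested is made for them only; others in the source may bear on it.

Of the compounds shown here, three built on one shared core have been measured in an ADME assay on HUVEC cells (Homo sapiens) for cytotoxicity, read by MTT assay, with a stated time of 48 h; a lower number here means a stronger inhibitor, a higher number a weaker inhibitor. Compound 1 `Nc1nc(-c2ccccc2)cn1/N=C/c1cc2ccccc2nc1Cl` gives 46700 nM. Compound 2 `COc1ccc(-c2cn(/N=C/c3cc4cc(C)ccc4nc3Cl)c(N)n2)cc1` gives 12200 nM, the lowest of the two numbers; compound 1 sits at a higher number, and that gap is beyond the scatter. For compound 3 `Nc1nc(-c2cccc3ccccc23)cn1/N=C/c1cc2ccccc2nc1Cl` the assay reports only a limit, > 50000 nM, not a number. That limit is the one described by the limit of > 50000 nM in this assay, at which 1 of the 3 values shown sits.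

The unmeasured compound 4 `Cc1ccc2nc(Cl)c(/C=N/n3cc(-c4cccs4)nc3N)cc2c1` differs from compound 2 in one place: thiophen-2-yl in place of 4-methoxyphenyl on an aromatic carbon. For the measured compounds named here, no measured pair differs in only this place, so the step has no direct precedent; compound 1 and compound 2 differ in two places at once and do not separate the aryl swap from the rest. A step no larger than the scatter is expected. Compound 4 is expected to give 18000 nM, with a range from 6000 nM to 50000 nM. The expected step from compound 2 to compound 4 is a 1.5-fold higher number from compound 2 to compound 4 (0.17 log units; within the scatter), within the scatter.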

Compound 4, half-maximal inhibitory concentration: 38000 nM
Estimate against measurement, compound 4: 2.1-fold (0.32 log units) below; the range from low to high includes it.
By their numbers in this assay, from the lowest: compound 2; then compounds 4 and 1 (each within the scatter of the next). At a limit, above all of these: compound 3.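

In this assay, the swap of 4-methoxyphenyl for thiophen-2-yl gives the first step readable in one place, a 3.1-fold higher number from compound 2 to compound 4 (0.49 log units; beyond the scatter) and it lies beyond the scatter. The aromatic carbon of the five-membered aromatic ring with 2 nitrogen therefore responds to the aryl group it carries, and here the five-membered thiophen-2-yl stands on the side of the higher number, though the step is only modest. No measured property shown bears on why this step occurs.

As far as these compounds go, a single swap cannot show a trend at this carbon, and whether the same swap would give a similar step on the core of compound 1 remains open. Also open, from the compounds shown here alone, is how this position would respond to a non-aromatic group, such as an amine, a carboxylic acid or a longer chain.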